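The source may hold more compounds than are shown below. What is called first, only, known or untested is meant among the compounds shown, and "the series" means these compounds.

Measured compounds in a functional assay on HCT-116 cells (Homo sapiens) for antiproliferative activity, read by CCK-8 assay, with a stated time of 72 h, tested at 2 uM; a lower number here means a weaker effect, a higher number a stronger effect of the compound at the concentration tested:

Compound 1 `CC1CCN(c2nc(Cl)nc3c2ncn3Cc2ccc(/C=C/C(=O)Nc3ccccc3N)cc2)CC1` gives 4.24%.
Compound 2 `Nc1ccccc1NC(=O)/C=C/c1ccc(Cn2cnc3c(Nc4cccc(Cl)c4)nc(Cl)nc32)cc1` gives 12.9%.
Compound 3 `CC1CCN(c2nc(Cl)nc3c2ncn3Cc2ccc(C(=O)Nc3ccccc3N)cc2)CC1` gives 70.9%.

Compound 3 is the most active of the three, and its margin over the other two is beyond the usual scatter. Two structural changes connect these compounds. The first is the change ((3-chlorophenyl)amino in place of 4-methylpiperidin-1-yl on an aromatic carbon), which gave a number 8.7 percentage points higher from compound 1 to compound 2 (within the scatter). The second alters the core: (2-aminophenyl)carbamoyl in place of 2-((2-aminophenyl)carbamoyl)ethenyl on an aromatic carbon, which gave a number 66.7 percentage points higher from compound 1 to compound 3 (beyond the scatter).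

Compound 4 `Nc1ccccc1NC(=O)c1ccc(Cn2cnc3c(Nc4cccc(Cl)c4)nc(Cl)nc32)cc1` has not yet been measured in this assay. It differs from compound 3 by (3-chlorophenyl)amino in place of 4-methylpiperidin-1-yl on an aromatic carbon, the same change already seen from compound 1 to compound 2, made at the same place and on the core of compound 3 rather than that of compound 1.

Among the compounds with values here, because that earlier change gave a number 8.7 percentage points higher from compound 1 to compound 2 (within the scatter), a step of similar size is expected here, that is a number 3.1 percentage points higher from compound 3 to compound 4 (within the scatter), with the caution that only one prior example exists and it sits on a different core. Compound 4 is therefore estimated at 74% in this assay, expected to lie between 52% and 92%.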

Compound 4, a percentage reported as inhibition, at one concentration (the size of the read-out at that concentration, not a potency): 56.2%
Compound 4: the middle estimate sits 17.8 percentage points above what was measured; the measured number falls inside the stated range.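

In this assay, putting (3-chlorophenyl)amino in place of 4-methylpiperidin-1-yl gave a number 14.7 percentage points lower from compound 3 to compound 4 (beyond the scatter), so this change does not carry over unaltered from one core to the other: the same change on two cores in this assay, a number 8.7 percentage points higher (within the scatter) from compound 1 to compound 2 and a number 14.7 percentage points lower (beyond the scatter) from compound 3 to compound 4, 23.4 percentage points apart, beyond the scatter of two such steps. Replacing 2-((2-aminophenyl)carbamoyl)ethenyl with (2-aminophenyl)carbamoyl gave a number 43.3 percentage points higher from compound 2 to compound 4 (beyond the scatter), which keeps the direction seen before but not the size: the same change on two cores in this assay, a number 66.7 percentage points higher (beyond the scatter) from compound 1 to compound 3 and a number 43.3 percentage points higher (beyond the scatter) from compound 2 to compound 4, 23.4 percentage points apart, beyond the scatter of two such steps. These two comparisons rest on the same four compounds and so show one observation, that the two changes do not act independently of each other; they do not show why, and they do not give a potency, since each read-out comes from a single concentration.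

As far as these compounds go, it remains open whether a different amine at the same place, such as morpholine or a simple benzylamine, would follow the 4-methylpiperidin-1-yl or the (3-chlorophenyl)amino compounds. From the compounds shown here alone, it is also open how a saturated chain in place of the ethenyl link, or a hydroxamic acid in place of the (2-aminophenyl)carbamoyl group, would behave on either core.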